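A few compounds are considered here, and "the series" means these few. Any claim that something is new, unique, unknown or untested is made for them only; others in the source may bear on it.

Measured in a physicochemical assay for solubility, read by spectrophotometry, in phosphate buffer, with a stated time of 18 h, at pH 7.4; a lower number here means a less soluble compound, a higher number a more soluble compound

Compound 1 `CCCc1ccc(-c2nc3c(c(C)nn3-c3ccccc3)c(-c3ccccc3O)c2C#N)cc1` gives 6500 nM
Compound 2 `Cc1nn(-c2ccccc2)c2nc(-c3ccc(F)cc3)c(C#N)c(-c3ccccc3O)c12` gives 6000 nM
Compound 3 `Cc1nn(-c2ccccc2)c2nc(-c3ccc(Cl)cc3)c(C#N)c(-c3ccccc3O)c12` gives 3800 nM

All three values lie within the usual scatter of one another, so compound 3 stands level with compound 1 and compound 2 on these numbers. Compound 4 `Cc1nn(-c2ccccc2)c2nc(-c3ccc4c(c3)CCCC4)c(C#N)c(-c3ccccc3O)c12` differs from compound 3 in one place, with 1,2,3,4-tetrahydronaphthalen-6-yl in place of 4-chlorophenyl on an aromatic carbon on an aromatic carbon. Three measured steps change this same part of the molecule, namely a 1.1-fold lower number from compound 1 to compound 2 (0.03 log units; within the scatter) and a 1.7-fold lower number from compound 1 to compound 3 (0.23 log units; within the scatter) and a 1.6-fold lower number from compound 2 to compound 3 (0.20 log units; within the scatter) and all of them stay within the scatter. No step beyond the scatter is therefore expected in this assay for compound 4. For the measured compounds named here, still, no measured compound carries the non-aromatic ring that enters here, so the expected range is kept wide. The expected step is a 1.1-fold higher number from compound 3 to compound 4 (0.02 log units; within the scatter) by this estimate. Compound 4 is estimated at 4000 nM with an expected range from 1500 nM to 9000 nM in this measurement.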

Compound 4, solubility: 13000 nM
Compound 4: the middle estimate sits 3.3-fold (0.51 log units) below what was measured, outside the stated range (above it).
By their numbers in this assay, from the lowest: compounds 3, 2, 1 and 4 (each within the scatter of the next, the first and the last beyond it).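

This position can move the number beyond the scatter in this assay: with the 1,2,3,4-tetrahydronaphthalen-6-yl group in place, the data show a 3.4-fold higher number from compound 3 to compound 4 (0.53 log units; beyond the scatter) and a 2.2-fold higher number from compound 2 to compound 4 (0.34 log units; beyond the scatter), whereas swaps among the earlier 4-substituted phenyl groups all stayed within it. The new group does not separate from every earlier one, as the comparison with the 4-propylphenyl group gives a 2.0-fold higher number from compound 1 to compound 4 (0.30 log units; within the scatter) and so compound 4 stands level with compound 1. Nothing measured here offers an explanation for these steps.

Still open, going by these compounds, is whether the non-aromatic ring itself matters, or whether an open chain such as a 4-butylphenyl group would give the same number. Also open, on these data alone, is how an amine or a carboxylic acid on the phenyl ring at this position would compare.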